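The source may hold more compounds than are shown below. What is called first, only, known or untested is meant among the compounds shown, and "the series" means these compounds.

Compound 1, `Oc1ccc(C2CC(c3ccccc3)=NN2c2ccc(Cl)cc2)cc1`: 3500 nM
Compound 2, `Oc1ccc(C2CC(c3ccccc3O)=NN2c2cccc(Cl)c2)cc1F`: 2900 nM

Of the compounds shown here, two have so far been measured in an assay on isolated protein for inhibition of protein kinase C zeta type (Homo sapiens), with a stated time of 4 min; a higher number here means a weaker inhibitor, a lower number a stronger inhibitor. Compound 2 gives 2900 nM, the lowest of the two numbers, and compound 1 gives 3500 nM, a difference within the scatter. Compound 3 `Oc1ccccc1C1=NN(c2cccc(Cl)c2)C(c2ccc(O)c(F)c2F)C1` has not yet been measured; it differs from compound 2 by fluoro in place of hydrogen on an aromatic carbon. For the measured compounds named here, no measured pair shows this change, so no step beyond the scatter is expected in either direction. Compound 3 is estimated at 2800 nM, with a range from 1200 nM to 6500 nM. The step of a 1.0-fold lower number from compound 2 to compound 3 (0.02 log units; within the scatter) is expected to stay within the scatter.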

Compound 3, half-maximal inhibitory concentration: 6600 nM
The estimate for compound 3 lay 2.4-fold (0.37 log units) below the measured number, and the stated range ends below it.
By their numbers in this assay, from the lowest: compounds 2, 1 and 3 (each within the scatter of the next, the first and the last beyond it).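

In this assay the change from 3-fluoro-4-hydroxyphenyl to 2,3-difluoro-4-hydroxyphenyl gives a 2.3-fold higher number from compound 2 to compound 3 (0.36 log units; beyond the scatter) and is the first step beyond the scatter among these compounds. It shows that this aromatic carbon, ortho to a fluoro group and meta to a hydroxy group, does not take a fluoro group without a modest weakening of inhibition. Nothing available gives a reason for this step. Going by these compounds, whether a chloro, methyl or methoxy group on the same carbon would weaken inhibition likewise stays open.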